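Swapping One Aromatic Group on a Shared Core

The source may hold more compounds than are shown below. What is called first, only, known or untested is meant among the compounds shown, and "the series" means these compounds.

Measured compounds:
compound 1 `COc1cccc(CNCCCNc2ccnc3cc(Cc4ccccc4)ccc23)c1O`: 23 10^-6 cm/s
compound 2 `COc1ccc(-c2ccc3c(NCCCNCc4ccco4)ccnc3c2)cc1`: 237 10^-6 cm/s

Two compounds sharing one core have been run in an ADME assay for permeability, using PAMPA, with a stated time of 30 min, at pH 7.4; on this read-out lower numbers stand for lower permeability and higher numbers for higher permeability. Compound 2 gives 237 10^-6 cm/s, and compound 1 gives 23 10^-6 cm/s. Compound 2 therefore has the highest number of the two, with compound 1 standing well beyond the usual scatter below it. The two differ in more than one place, so their gap is simply what the two numbers show and is not traced to any single change.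

Compound 3 `c1ccc(Cc2ccc3c(NCCCNCc4ccco4)ccnc3c2)cc1` has not yet been measured. It differs from compound 2 in one place: benzyl in place of 4-methoxyphenyl on an aromatic carbon. The group that leaves carries one hydrogen-bond acceptor; the benzyl group that enters carries none. Among the measured compounds shown here, there is no measured pair in this set that isolates this exchange, so the step has to be guessed from the change alone. A small step is expected, if any, with the number for compound 3 staying within the scatter of compound 2, the step from compound 2 to compound 3 being estimated as a 1.2-fold lower number from compound 2 to compound 3 (0.07 log units; within the scatter). For compound 3 the expected value in this assay is 200 10^-6 cm/s, with a range from 80 10^-6 cm/s to 400 10^-6 cm/s.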

Compound 3, apparent permeability: 23 10^-6 cm/s
Compound 3: middle estimate off by 8.7-fold (0.94 log units), on the high side; measured number below the stated range.
By their numbers in this assay, from the lowest: compounds 1 and 3 (each within the scatter of the next); then compound 2.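

In this assay, benzyl in place of 4-methoxyphenyl on this aromatic carbon gives a 10-fold lower number from compound 2 to compound 3 (1.01 log units; beyond the scatter) and so shows that the number can depend strongly on which group sits here, even though both groups carry one six-membered aromatic ring of carbon only. With benzyl held at this position, furan-2-yl in place of 2-hydroxy-3-methoxyphenyl on a saturated chain carbon bound to an amine nitrogen gives no change at the digits printed from compound 1 to compound 3 (within the scatter) and stays within the scatter, so the read-out does not respond to every aromatic exchange on this scaffold in the same way. Nothing measured here says what lies behind the large step.

Going by these compounds, it remains open whether the step follows the methoxy group or the carbon link in benzyl, and a plain phenyl group or a 4-methoxybenzyl group on this carbon would help separate the two. It is also open whether the furan-2-yl exchange would remain this small with 4-methoxyphenyl on the core, as the pair shown reads that exchange only with benzyl present.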